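This account rests on a few compounds, and the source may have more. Where it says the series, first, only, none or still open, it means among the compounds named here.

Measured compounds:
Compound 1, `CC(C(=O)NCc1ccc(Br)cc1)c1ccc(NS(C)(=O)=O)c(F)c1`, 250 nM
Compound 2, `Cc1ccc(CNC(=O)C(C)c2ccc(NS(C)(=O)=O)c(F)c2)cc1`, 930 nM

Compound 2 holds the highest number of the two in a functional assay on CHO cells for antagonist activity at transient receptor potential cation channel subfamily V member 1 (Rattus norvegicus); a lower number here means a stronger inhibitor, a higher number a weaker inhibitor; its nearest neighbour is compound 1, with a 3.7-fold higher number from compound 1 to compound 2 (0.57 log units; beyond the scatter) on going to compound 2. Compound 3, `CC(C(=O)NCc1ccc(C2CC2)cc1)c1ccc(NS(C)(=O)=O)c(F)c1`, differs from compound 2 only in that (cyclopropyl in place of methyl on an aromatic carbon). Within the data shown here, the one measured step that touches this position is the change at the same aromatic carbon from compound 1 to compound 2, which gave a 3.7-fold higher number from compound 1 to compound 2 (0.57 log units; beyond the scatter), so a change of the group there can move this assay beyond the scatter; no measured pair shows cyclopropyl itself. Compound 3 is therefore expected to show a modest step, more likely downward, a 1.9-fold lower number from compound 2 to compound 3 (0.27 log units; within the scatter), in this assay. The estimate for compound 3 in this assay is 500 nM, with a range from 150 nM to 1600 nM.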

Compound 3, inhibition constant: 55.5 nM
Estimate against measurement, compound 3: 9.0-fold (0.95 log units) above, outside the stated range (below it).
By their numbers in this assay, from the lowest: compound 3; then compound 1; then compound 2.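

In this assay, the group on this aromatic carbon, para to a large group, can shift the number much further than the earlier pair revealed: cyclopropyl in place of methyl gives a 17-fold lower number from compound 2 to compound 3 (1.22 log units; beyond the scatter), a large step where the change from bromo to methyl was modest. Cyclopropyl in place of bromo also gives a 4.5-fold lower number from compound 1 to compound 3 (0.65 log units; beyond the scatter), so compound 3 is the strongest inhibitor of the three and the earlier best group at this position, bromo, is surpassed. Nothing available explains why cyclopropyl stands apart from methyl and bromo.

The compounds shown leave open whether the three-membered ring itself matters or whether an isopropyl group, with the same carbon count but no ring, would serve equally well. They also leave open how a cyclobutyl ring or a methoxy group would fare on this carbon.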